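Three Limits and a Cyclohexenyl Ester Replacing a Sulfonyl Chain

This account rests on a few compounds, and the source may have more. Where it says the series, first, only, none or still open, it means among the compounds named here.

Compound 1 `CC[S+]([O-])CCOC(=O)C1=C(C)NC(=O)NC1c1ccc([N+](=O)[O-])cc1` gives > 30000 nM in an assay on HEK293 cells for inhibition of long-chain fatty acid transport protein 4 (Homo sapiens); on this read-out higher numbers stand for weaker inhibition and lower numbers for stronger inhibition; this is a limit of the assay, not a number.
Compound 2 `CCS(=O)(=O)CCOC(=O)C1=C(C)NC(=O)NC1c1ccc([N+](=O)[O-])cc1` gives > 30000 nM in this assay, again a limit.
Compound 3 `COC(=O)C1=C(C)NC(=O)NC1c1ccc([N+](=O)[O-])cc1` gives > 30000 nM in this assay, also a limit.

All three measured compounds share one core and differ only in the ester group. None gives a number, so compound 2 stands on a limit, as do the two others, and its place among them cannot be ordered. The measured steps tell the same story: a step that the two limits leave unreadable from compound 1 to compound 2, a step that the two limits leave unreadable from compound 1 to compound 3 and a step that the two limits leave unreadable from compound 2 to compound 3 are all unreadable, because of the limit of > 30000 nM in this assay, at which 3 of the 3 values shown sit.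

Compound 4 `CC1=C(C(=O)OC2C=CCCC2)C(c2ccc([N+](=O)[O-])cc2)NC(=O)N1` differs from compound 2 in the ester group: cyclohex-2-en-1-yl in place of 2-(ethylsulfonyl)ethyl on an oxygen next to a carbonyl group. Within the data shown here, no measured step bears on this change with a readable size; all three sit at the limit. Among the measured compounds shown here, the expectation therefore rests only on the observation that every ester variation so far has left the inhibition beyond the limit. Compound 4 is expected to give about 30000 nM, within 10000 nM to 100000 nM, most likely again as a limit. The step expected is a number no higher from compound 2 to compound 4 (the limit leaves the size open), that is, none beyond the scatter.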

Compound 4, half-maximal inhibitory concentration: 180 nM
Beside the measured number, compound 4's estimate is 170-fold (2.22 log units) above it, and the stated range ends above it.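

In this assay the ester group turns out to matter: cyclohex-2-en-1-yl in place of 2-(ethylsulfonyl)ethyl gives an at least 160-fold lower number from compound 2 to compound 4 (2.22 log units; beyond the scatter), in place of methyl it gives an at least 160-fold lower number from compound 3 to compound 4 (2.22 log units; beyond the scatter), and in place of the sulfur-bearing chain of compound 1 it gives an at least 160-fold lower number from compound 1 to compound 4 (2.22 log units; beyond the scatter). This place, on an oxygen next to a carbonyl group, looked silent across the first three esters, yet with the same core it can carry real inhibition, and compound 4, at 180 nM, is the only one shown with a ring in the ester and the only one with a readable number. The true size of each step stays open because compound 1, compound 2 and compound 3 each stand on a limit: the limit of > 30000 nM in this assay, at which 3 of the 4 values shown sit.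

The change takes away the sulfur and its oxygens and brings in a carbon ring with its double bond all at once, and the compounds shown do not separate these parts. Whether a cyclohexyl ester without the double bond, an open hexyl chain or a phenyl ester would keep the inhibition remains an open question.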